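The source may report more compounds than this note shows. Statements on the series, on what has been measured and on what is new or still open speak of the compounds shown alone.

Measured in a functional assay on CCRF-CEM cells (Homo sapiens) for antiproliferative activity; a higher number here means a weaker inhibitor, a lower number a stronger inhibitor:
Compound 1 `COc1cc(C(=O)c2sc(-c3ccccc3)cc2N)cc(OC)c1OC`: 4.5 nM
Compound 2 `COc1cc(C(=O)c2sc(-c3ccsc3)cc2N)cc(OC)c1OC`: 9.6 nM

Of these two, compound 2 has the higher number, 9.6 nM, so it is the weaker inhibitor of the pair. The next compound, compound 3 `COc1cc(C(=O)c2sc(-c3ccc(F)cc3)cc2N)cc(OC)c1OC`, is reached from it by one change on the aromatic carbon next to the ring sulfur: 4-fluorophenyl in place of thiophen-3-yl (4-fluorophenyl in place of thiophen-3-yl on an aromatic carbon). For the measured compounds named here, one measured step bears on this, at the same place, with thiophen-3-yl in place of phenyl: a 2.1-fold higher number from compound 1 to compound 2 (0.33 log units; beyond the scatter). Going by the values given here, no measured step shows what a fluorine adds to the phenyl. If compound 3 follows compound 1, with its 4.5 nM, a modest move to a lower number is expected in this assay, and it may not clear the scatter: a 1.6-fold lower number from compound 2 to compound 3 (0.20 log units; within the scatter). For compound 3 the estimated value is 6 nM, with an expected range from 2.5 nM to 15 nM.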

Compound 3, half-maximal inhibitory concentration: 15 nM
Compound 3: middle estimate off by 2.5-fold (0.40 log units), on the low side; low and high end bracket the measured number.
By their numbers in this assay, from the lowest: compound 1; then compounds 2 and 3 (each within the scatter of the next).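

With the assay named in full, this assay, fluoro in place of hydrogen on the phenyl gives a 3.3-fold higher number from compound 1 to compound 3 (0.52 log units; beyond the scatter), so a change within the aryl group at this position, and not only a change of ring, moves the number beyond the scatter. The exchange of thiophen-3-yl for 4-fluorophenyl gives a 1.6-fold higher number from compound 2 to compound 3 (0.19 log units; within the scatter), so these two groups cannot be told apart here, and both stand beyond the scatter from the unsubstituted phenyl of compound 1. Nothing on hand explains these differences.

The compounds shown leave open whether the step from compound 1 belongs to fluorine itself or would also follow a chlorine, methyl or methoxy group on the phenyl. They also leave open how an amine or a carboxylic acid on that ring would read in this assay.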